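A few compounds are considered here, and "the series" means these few. Any claim that something is new, unique, unknown or untested is made for them only; others in the source may bear on it.

In a functional assay on MCF7 cells (Homo sapiens) for cytotoxicity, read by MTT assay, with a stated time of 72 h (on this read-out higher numbers stand for weaker inhibition and lower numbers for stronger inhibition), compound 1 `O=C(Nc1ccc(Oc2ccnc3[nH]ccc23)cc1)c1nn(-c2ccccc2)ccc1=O` gives 15600 nM and compound 2 `O=C(Nc1ccc(Oc2ccnc3[nH]ccc23)cc1)c1nn(-c2ccc(Br)cc2F)ccc1=O` gives 17900 nM, the highest of the two numbers, with compound 1 nearest and within the scatter. For the measured compounds named here, the only measured step, a 1.1-fold higher number from compound 1 to compound 2 (0.06 log units; within the scatter), replaces the phenyl on the aromatic nitrogen with a halogenated phenyl and stays within the scatter. Compound 3 `O=C(Nc1ccc(Oc2ccnc3[nH]ccc23)cc1)c1nn(-c2ccc(Cl)c(F)c2)ccc1=O` carries 4-chloro-3-fluorophenyl in place of 4-bromo-2-fluorophenyl on an aromatic nitrogen. Because a 1.1-fold higher number from compound 1 to compound 2 (0.06 log units; within the scatter) stayed within the scatter, no step beyond the scatter is expected here, and a 1.1-fold lower number from compound 2 to compound 3 (0.02 log units; within the scatter) is the expected size. Compound 3 is therefore estimated at 17000 nM, with a range from 8000 nM to 36000 nM.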

Compound 3, half-maximal inhibitory concentration: 3110 nM
Beside the measured number, compound 3's estimate is 5.5-fold (0.74 log units) above it; the whole stated range lies above it.
By their numbers in this assay, from the lowest: compound 3; then compounds 1 and 2 (each within the scatter of the next).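

Changing the group on the aromatic nitrogen can move the number in this assay beyond the scatter, with a 5.8-fold lower number from compound 2 to compound 3 (0.76 log units; beyond the scatter) and with a 5.0-fold lower number from compound 1 to compound 3 (0.70 log units; beyond the scatter) in this series. Halogens on this phenyl do not by themselves decide the outcome: compound 2 stays within the scatter of compound 1, whereas compound 3 does not. No evidence on the origin of these steps is available.

The swap from compound 2 to compound 3 alters both the halogens and their placement, so the two remain unseparated. On these data alone, how a methoxy group or an amine on this phenyl would read remains open.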